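The source may report more compounds than this note shows. Statements on the series, on what has been measured and on what is new or still open speak of the compounds shown alone.

Three compounds share one core and differ at a single ring carbon. Compound 3 `Cc1noc(NS(=O)(=O)c2cccc3ccccc23)c1C` carries only a hydrogen at that carbon; in an assay on VSM-A10 cells for antagonist activity at Endothelin-1 receptor (Rattus norvegicus) (a higher number here means a weaker inhibitor, a lower number a stronger inhibitor), compound 3 gives 20000 nM, the highest number of the three. Compound 1 `Cc1noc(NS(=O)(=O)c2cccc3c(N4CCCCC4=O)cccc23)c1C` carries a 2-oxopiperidin-1-yl group there and gives 270 nM in this assay; compound 2 `Cc1noc(NS(=O)(=O)c2cccc3c(N4CCCC4=O)cccc23)c1C` carries a 2-oxopyrrolidin-1-yl group and gives 130 nM. Taking either ring away costs a great deal: a 74-fold higher number from compound 1 to compound 3 (1.87 log units; beyond the scatter) and a 150-fold higher number from compound 2 to compound 3 (2.19 log units; beyond the scatter). Compound 4 `Cc1noc(NS(=O)(=O)c2cccc3c(NC(C)C)cccc23)c1C` has not yet been measured. It differs from compound 3 by isopropylamino in place of hydrogen on an aromatic carbon. The two measured steps show that a group at this carbon brings the number down strongly, so a downward step is expected here as well. Isopropylamino has no ring, unlike the two lactam groups, and no measured compound carries such a group, so the expected gain is taken to be smaller and less certain. Compound 4 is therefore estimated at 1500 nM in this assay, with a range from 400 nM to 6000 nM, which corresponds to an expected step of a 13-fold lower number from compound 3 to compound 4 (1.12 log units; beyond the scatter).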

Compound 4, half-maximal inhibitory concentration: 20 nM
Compound 4: middle estimate off by 75-fold (1.88 log units), on the high side; measured number outside the range, below it.
By their numbers in this assay, from the lowest: compound 4; then compound 2; then compound 1; then compound 3.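

In this assay, a ring is not needed at this carbon, since the open-chain isopropylamino group gives a 1000-fold lower number from compound 3 to compound 4 (3.00 log units; beyond the scatter) and so brings a larger gain than either lactam ring. It also outperforms both lactam groups directly, with a 6.5-fold lower number from compound 2 to compound 4 (0.81 log units; beyond the scatter) and a 14-fold lower number from compound 1 to compound 4 (1.13 log units; beyond the scatter) and so compound 4 is the strongest inhibitor of the four. Isopropylamino differs from the lactam groups in more than one way at once, as it has neither their ring nor their carbonyl, so these steps cannot single out which difference matters.

On these data alone, whether a plain amino group, a longer alkylamino chain or an isopropyl group joined directly through carbon would perform as well remains open. No measurement shown here explains why isopropylamino gives the lowest number.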